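A few compounds are considered here, and "the series" means these few. Any claim that something is new, unique, unknown or untested is made for them only; others in the source may bear on it.

Measured compounds in a functional assay on CHO cells for antagonist activity at transient receptor potential cation channel subfamily V member 1 (Rattus norvegicus); on this read-out lower numbers stand for stronger inhibition and higher numbers for weaker inhibition:

- compound 1 `COc1cc(C2(C(=O)NCc3ccc(C(C)(C)C)cc3)CC2)ccc1NS(C)(=O)=O`: 2250 nM
- compound 2 `CC(NC(=O)/C=C/c1ccc(C(C)(C)C)cc1)c1ccc(NS(C)(=O)=O)c(F)c1`: 23.9 nM
- compound 3 `CC(C(=O)NCc1ccc(Br)cc1)c1ccc(NS(C)(=O)=O)c(F)c1`: 250 nM

Compound 3 holds the second highest of the three numbers. Its nearest neighbour is compound 1, with a higher number, a gap beyond the scatter; compound 2 lies furthest, with a lower number, a gap also beyond the scatter.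

Compound 4 `Cc1ccc(CNC(=O)C(C)c2ccc(NS(C)(=O)=O)c(F)c2)cc1` differs from compound 3 in one place: methyl in place of bromo on an aromatic carbon, para to a large group. Within the data shown here, no directly comparable pair among the measured compounds shows this change, so the expectation rests only on the three numbers above. The step of a 2.0-fold higher number from compound 3 to compound 4 (0.30 log units; within the scatter) is expected to be small and toward a weaker number, at the edge of the scatter. Compound 4 is estimated at 500 nM, within 200 nM to 1500 nM.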

Compound 4, inhibition constant: 930 nM
Compound 4: middle estimate off by 1.9-fold (0.27 log units), on the low side, within the range that was stated.
By their numbers in this assay, from the lowest: compound 2; then compound 3; then compound 4; then compound 1.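

In this assay, among these compounds, the change from 4-bromobenzyl to 4-methylbenzyl gives a 3.7-fold higher number from compound 3 to compound 4 (0.57 log units; beyond the scatter), the first comparison that isolates one place. The position para to a large group therefore responds to the exchange of one heavy atom for another, even though the counts of hydrogen-bond donors and acceptors stay the same. Of these two groups, bromo gives the stronger inhibition on the shared core. From the compounds shown here alone, whether chloro, methoxy or trifluoromethyl at this position would track bromo or methyl remains open. The reason for the step also remains open, with nothing available that bears on it.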